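Exchanging the ring group on sulfur: compound 3

A few compounds are considered here, and "the series" means these few. Any claim that something is new, unique, unknown or untested is made for them only; others in the source may bear on it.

In a functional assay on ECa-109 cells for antiproliferative activity against ECa-109 cell line (Homo sapiens), read by MTT assay, with a stated time of 48 h (a higher number here means a weaker inhibitor, a lower number a stronger inhibitor), compound 1 (`COc1ccc(CN(C(=O)CSc2nnnn2C)c2cc(OC)c(OC)c(OC)c2)cc1`) gives 5540 nM and compound 2 (`COc1ccc(CN(C(=O)CSc2nncs2)c2cc(OC)c(OC)c(OC)c2)cc1`) gives 9840 nM. These values lie within the scatter of each other, so compound 2 holds no clear place apart from compound 1. Compound 3 (`COc1ccc(CN(C(=O)CSc2nc3ccccc3o2)c2cc(OC)c(OC)c(OC)c2)cc1`) differs from compound 2 on a sulfur: 1,3-benzoxazol-2-yl in place of 1,3,4-thiadiazol-2-yl on a sulfur. The entering 1,3-benzoxazol-2-yl brings one six-membered aromatic ring of carbon only, which neither measured compound carries. Going by the values given here, the one measured step at this place is a 1.8-fold higher number from compound 1 to compound 2 (0.25 log units; within the scatter), so exchanging the group on this sulfur has so far moved the number by no more than the scatter. Among the compounds with values here, no measured step tests the added ring, so the direction stays open and the range wide. The estimate means a 1.6-fold lower number from compound 2 to compound 3 (0.21 log units; within the scatter), an expected step within the scatter. Compound 3 is expected at 6000 nM, with an estimated range of 1800 nM to 18000 nM.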

Compound 3, half-maximal inhibitory concentration: 24800 nM
Compound 3: the middle estimate sits 4.1-fold (0.62 log units) below what was measured; measured number outside the range, above it.
By their numbers in this assay, from the lowest: compounds 1 and 2 (each within the scatter of the next); then compound 3.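

In this assay the group on this sulfur can shift the number beyond the scatter: the change to 1,3-benzoxazol-2-yl gives a 2.5-fold higher number from compound 2 to compound 3 (0.40 log units; beyond the scatter) and a 4.5-fold higher number from compound 1 to compound 3 (0.65 log units; beyond the scatter) as its two steps. Going by these compounds alone, compound 3 is the only compound of the three with a six-membered aromatic ring of carbon only, and it has the highest number, but this single compound establishes no trend for that ring, since its five-membered ring also differs from those of compound 1 and compound 2. No available measurement explains this step.

The compounds shown leave open whether the higher number follows the fused benzene ring or the change in the five-membered ring, which a 1,3-benzothiazol-2-yl or plain phenyl group on this sulfur would help separate. They also leave open whether any group here can give a clearly lower number than the 1-methyl-1H-tetrazol-5-yl of compound 1.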